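This account rests on a few compounds, and the source may have more. Where it says the series, first, only, none or still open, it means among the compounds named here.

Compound 1 `CC1(C)CCC(C)(C)c2cc(C(=O)c3ccc(/C=C/C(=O)O)cc3)ccc21`: 63%
Compound 2 `C/C(=C\C(=O)O)c1ccc(C(=O)c2ccc3c(c2)C(C)(C)CCC3(C)C)cc1`: 0%

In a functional assay for activation of retinoic acid receptor alpha (Homo sapiens) (a higher number here means a larger maximal response, a lower number a smaller maximal response), compound 2 gives 0%, the lowest of the two numbers measured; its nearest neighbour is compound 1, which gives 63%. Among the compounds with values here, the only measured step, a number 63 percentage points lower from compound 1 to compound 2 (beyond the scatter), is the one that separates these two compounds.

Compound 3 `C/C(=C\c1ccc(C(=O)c2ccc3c(c2)C(C)(C)CCC3(C)C)cc1)C(=O)O` has not yet been measured in this assay. Its relation to compound 2 is 2-carboxyprop-1-en-1-yl in place of 2-carboxy-1-methylethenyl on an aromatic carbon. The measured step from compound 1 to compound 2 bears on this: adding the methyl to the alkene carbon at the aromatic ring abolished the response. Within the data shown here, compound 3 keeps the methyl but moves it to the carbon that carries the carboxylic acid, so the single step in hand does not settle the outcome. Compound 3 is estimated to recover part of the response, at 30% within 0% to 65%, an expected step of a number 30 percentage points higher from compound 2 to compound 3 (beyond the scatter).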

Compound 3, largest response reached (reported as maximum), in percent of the reference or control that the assay uses: 37%
Beside the measured number, compound 3's estimate is 7 percentage points below it; low and high end bracket the measured number.
By their numbers in this assay, from the lowest: compound 2; then compound 3; then compound 1.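

In this assay, putting 2-carboxyprop-1-en-1-yl in place of 2-carboxy-1-methylethenyl on the same aromatic carbon, para to a large group, gives a number 37 percentage points higher from compound 2 to compound 3 (beyond the scatter) with the same atoms joined differently, so in this pair the loss of response depends on where the methyl stands and not only on its presence. The methyl in its new place still comes at a cost, since replacing 2-carboxyethenyl with 2-carboxyprop-1-en-1-yl gives a number 26 percentage points lower from compound 1 to compound 3 (beyond the scatter) and the response is recovered only in part. Nothing available here explains why the two placements differ.

The compounds shown leave open whether an ethyl group or a fluorine in place of that methyl would keep the response of compound 3. They also leave open what a methyl on both alkene carbons would do.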